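Removing the methoxy group from compound 3

A few compounds are considered here, and "the series" means these few. Any claim that something is new, unique, unknown or untested is made for them only; others in the source may bear on it.

Compound 3 `CC#CCN(C)Cc1cc2cc(OC)ccc2n1C` gives 1.4 nM in an assay on isolated protein for inhibition of Amine oxidase [flavin-containing] A (Rattus norvegicus) (a lower number here means a stronger inhibitor, a higher number a weaker inhibitor), the second highest of the three numbers. Compound 2 `C#CCNCc1cc2cc(OC)ccc2n1C` gives 0.8 nM, within the scatter of compound 3, while compound 1 `C#CCNCc1cc2cc(O)ccc2n1C` gives 4000 nM, far higher. Compound 4 `CC#CCN(C)Cc1cc2ccccc2n1C` differs from compound 3 by hydrogen in place of methoxy on an aromatic carbon. Within the data shown here, no measured step removes the whole group from this ring carbon. Among the measured compounds shown here, the steps that bear on it are a 5000-fold lower number from compound 1 to compound 2 (3.70 log units; beyond the scatter), showing how strongly the number depends on what sits on that oxygen, and a 1.8-fold higher number from compound 2 to compound 3 (0.24 log units; within the scatter), a small change at the amine. Loss of the methoxy is therefore expected to raise the number, by an uncertain amount. The expected step is a 14-fold higher number from compound 3 to compound 4 (1.15 log units; beyond the scatter). Compound 4 is expected at 20 nM, range 2 nM to 200 nM.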

Compound 4, inhibition constant: 4.3 nM
For compound 4 the middle estimate is 4.7-fold (0.67 log units) above the measured one; measured number inside the range.
By their numbers in this assay, from the lowest: compounds 2 and 3 (each within the scatter of the next); then compound 4; then compound 1.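

In this assay the methoxy on this aromatic carbon is not essential for a low number, as hydrogen there gives a 3.1-fold higher number from compound 3 to compound 4 (0.49 log units; beyond the scatter) and compound 4 stays in the low nanomolar range. This modest loss is much smaller than a 5000-fold lower number from compound 1 to compound 2 (3.70 log units; beyond the scatter) seen at the oxygen of the same group with a different amine. A hydroxyl on this carbon therefore needs reading alongside the amine. Nothing at hand accounts for the gap between these two steps. Still open, going by these compounds, is how a fluorine, a chlorine or an ethoxy group on this carbon would read, and whether a hydroxyl with the (but-2-yn-1-yl)(methyl)amino chain would give as high a number as compound 1 gives with propargylamino.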